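The source may report more compounds than this note shows. Statements on the series, on what has been measured and on what is new or still open speak of the compounds shown alone.

Measured values in an assay on cells for inhibition of histone-lysine N-methyltransferase EZH2 (Homo sapiens), read by ELISA, with a stated time of 72 h; a lower number here means a stronger inhibitor, a higher number a weaker inhibitor:
- compound 1 `Cc1cc(C)c(CN2CCc3c(Cl)cc([C@@H](CO)[C@@H]4CCOC4)c(Cl)c3C2=O)c(=O)[nH]1`: 2910 nM
- compound 2 `COC(c1cc(Cl)c2c(c1Cl)C(=O)N(Cc1c(C)cc(C)[nH]c1=O)CC2)C1CCN(C2COC2)CC1`: 1310 nM; 16 nM (2 entries)
- compound 3 `COc1cc(C)[nH]c(=O)c1CN1CCc2c(Cl)cc([C@@H](O)C3COC3)c(Cl)c2C1=O`: > 32000 nM

For the measured compounds named here, compound 1 is the only member of the set with a single clean number in this assay. Going by the values given here, compound 2 does not give a single number: the several entries of compound 2 in this assay, 1310 nM; 16 nM (2 entries), and the two entries sit far apart, so no step from compound 1 to compound 2 can be drawn from them. The value of compound 3 is a limit of the assay, not a number, and (the limit of > 32000 nM in this assay, at which 1 of the 3 values shown sits). Compound 1 therefore stands alone as the reference point, with one limit and one unresolved entry beside it.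

Compound 4 `Cc1cc(C)c(CN2CCc3c(Cl)cc([C@H](CO)[C@@H]4CCCO4)c(Cl)c3C2=O)c(=O)[nH]1` is built from the same atoms as compound 1, joined differently: a group of 8 heavy atoms (6 carbon, 2 oxygen; one five-membered non-aromatic ring with 1 hetero atom) in place of a group of 8 heavy atoms (6 carbon, 2 oxygen; one five-membered non-aromatic ring with 1 hetero atom), on an aromatic carbon. With no measured step of this kind in the set, no direction can be read from the data; the working assumption is a step of the order of the scatter, or none beyond it.

For compound 4 in this assay the expected step is a 1.2-fold lower number from compound 1 to compound 4 (0.07 log units; within the scatter), which is estimated as essentially flat. The estimate for compound 4 is 2500 nM, expected to fall between 700 nM and 9000 nM.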

Compound 4, half-maximal inhibitory concentration: 41 nM
Estimate against measurement, compound 4: 61-fold (1.79 log units) above; the whole stated range lies above it.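

In this assay the series now has its first readable step, a 71-fold lower number from compound 1 to compound 4 (1.85 log units; beyond the scatter), and it is a large one. The groups that trade places on this aromatic carbon, ortho to a chloro group, have the same atoms, the same hydrogen-bond donor and acceptor counts and the same number of defined stereocentres, so the position separates the two compounds by how those atoms are joined, not by their composition. Compound 2, with its widely split entries, and compound 3, whose value is a limit, give no step to set beside this one, and nothing shown accounts for its size.

Still open, going by these compounds, is whether the step follows from how the five-membered ring is attached or from the arrangement at the stereocentres, which this single pair cannot settle. Also open, on these data alone, is how the same position responds to a six-membered ring ether in place of the five-membered ring, or to a carboxylic acid or primary amine in place of the hydroxyl.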